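The compounds below may be only part of what the source reports. "The series", "measured", "known", "first", "only" and "open" are said of these compounds alone.

In a functional assay on the whole organism for antagonist activity, with Mus musculus as the target (a lower number here means that less compound is needed, a higher number that more compound is needed for the effect), compound 1 `O=C1NCCN1CC#CCn1ccnc1` gives only a limit, > 100 mg/kg. Compound 2 `CN1CCN(CC#CCn2ccnc2)C1=O` also gives only a limit, > 100 mg/kg. Compound 2 thus stands at the limit of > 100 mg/kg in this assay, at which 2 of the 3 values shown sit, and no number fixes its true place. Compound 3 `Cc1cncn1CC#CCN1CCN(C)C1=O` gives a real number, 14 mg/kg.

Compound 4 `CC(C#CCn1ccnc1)N1CCN(C)C1=O` differs from compound 2 by methyl in place of hydrogen on a saturated chain carbon bound to an amide-type nitrogen in a ring and a triple-bonded carbon. Neither measured step touches this place, so both bear on it only loosely. Methyl in place of hydrogen on an amide-type nitrogen in a ring gives a step that the two limits leave unreadable from compound 1 to compound 2, which offers no guidance on size. Methyl in place of hydrogen on an aromatic carbon gives an at least 7.1-fold lower number from compound 2 to compound 3 (0.85 log units; beyond the scatter), and this is the only readable step. It is also the only one that puts a methyl on carbon, but on a different kind of carbon. A smaller step in the same direction is therefore expected in this assay, and another limit would be no surprise. The expected change is an at least 1.4-fold lower number from compound 2 to compound 4 (0.15 log units; that floor lies within the scatter). For compound 4 the estimate is 70 mg/kg, with an expected range from 15 mg/kg to 300 mg/kg.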

Compound 4, dose for half-maximal effect: 21 mg/kg
Estimate against measurement, compound 4: 3.3-fold (0.52 log units) above; low and high end bracket the measured number.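

In this assay, methyl in place of hydrogen on a saturated chain carbon bound to an amide-type nitrogen in a ring and a triple-bonded carbon gives an at least 4.7-fold lower number from compound 2 to compound 4 (0.67 log units; beyond the scatter). The earlier compounds shown here showed such a gain only for a methyl on an aromatic carbon, so this result adds a second place at which one added methyl, a single carbon with no hydrogen-bond donors or acceptors, turns a limit into a real number. The step gives only a floor and its full size stays unknown because its starting point is a limit rather than a number: the limit of > 100 mg/kg in this assay, at which 2 of the 4 values shown sit.

The compounds shown leave open whether the gain at this chain carbon is particular to methyl or would also appear with an ethyl group, a hydroxymethyl group or a second methyl on the same carbon. They also leave open how a methyl on this chain carbon and a methyl on the aromatic carbon would behave together in one molecule, whether their steps would add up or one would make the other redundant.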